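A few compounds are considered here, and "the series" means these few. Any claim that something is new, unique, unknown or untested is made for them only; others in the source may bear on it.

Measured compounds:
compound 1 `O=C(O)c1ccccc1-c1ccc(CCc2ncc(Cc3ccccc3F)[nH]2)cc1` — 9.5 nM
compound 2 `O=C(O)c1ccccc1-c1ccc(CCc2ncc(Cc3ccc(Cl)cc3)[nH]2)cc1` — 102 nM
compound 3 `O=C(O)c1ccccc1-c1ccc(CCc2ncc(Cc3cccc(F)c3)[nH]2)cc1` — 7.9 nM

In an in vitro functional assay on cells for agonist activity at Bombesin receptor subtype-3 (Mus musculus), read by luminescence and calcium flux (on this read-out higher numbers stand for an effect only at larger amounts of compound and lower numbers for an effect already at smaller amounts), compound 3 gives the lowest number of the three, yet the step of a 1.2-fold lower number from compound 1 to compound 3 (0.08 log units; within the scatter) lies within the scatter, so compound 1 and compound 3 cannot be ranked. Compound 2 stands well apart: a 13-fold lower number from compound 2 to compound 3 (1.11 log units; beyond the scatter).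

Compound 4 `CC(C)(C)Cc1cnc(CCc2ccc(-c3ccccc3C(=O)O)cc2)[nH]1` differs from compound 3 in one place: tert-butyl in place of 3-fluorophenyl on a saturated chain carbon bound to an aromatic carbon. Going by the values given here, none of the measured steps removes the aromatic ring at this place; they only move or exchange a single halogen on it. Those steps show that the spot is sensitive: a fluorine shifted around the ring left the number nearly unchanged a 1.2-fold lower number from compound 1 to compound 3 (0.08 log units; within the scatter), while a chlorine in another position raised it sharply an 11-fold higher number from compound 1 to compound 2 (1.03 log units; beyond the scatter). Replacing the whole ring with a tert-butyl group is a larger change than any of these, so a noticeably higher number than compound 3 is expected, though with wide uncertainty.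

Compound 4 is therefore estimated at 60 nM, with a range from 10 nM to 400 nM; the expected step is a 7.6-fold higher number from compound 3 to compound 4 (0.88 log units; beyond the scatter).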

Compound 4, half-maximal effective concentration: 6.3 nM
Compound 4: the middle estimate sits 9.5-fold (0.98 log units) above what was measured; measured number outside the range, below it.
By their numbers in this assay, from the lowest: compounds 4, 3 and 1 (each within the scatter of the next); then compound 2.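

In this assay the aromatic ring at this place turns out not to be required: a 1.3-fold lower number from compound 3 to compound 4 (0.10 log units; within the scatter) and a 1.5-fold lower number from compound 1 to compound 4 (0.18 log units; within the scatter) both stay within the scatter, so tert-butyl, with no ring and 4 heavy atoms in place of 7, matches the 3-fluorophenyl and 2-fluorophenyl groups. At the same time, a 16-fold lower number from compound 2 to compound 4 (1.21 log units; beyond the scatter) shows that the high number of compound 2 belongs to the 4-chlorophenyl group and is not a general result of changing the fluorophenyl group. Nothing at hand gives a reason for either result.

Going by these compounds, it remains open whether a smaller group such as methyl, or a chain carrying an amine or a hydroxyl, would be accepted here as well. On these data alone, it also remains open whether the high number of compound 2 goes with the chlorine itself or with where it sits on the ring.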